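Isopropyl in place of isobutyl on a sulfonamide nitrogen

A few compounds are considered here, and "the series" means these few. Any claim that something is new, unique, unknown or untested is made for them only; others in the source may bear on it.

Among the measured compounds shown here, only two compounds have numbers so far in a functional assay on MV4-11 cells (Homo sapiens) for inhibition, with a stated time of 72 h; a higher number here means a weaker inhibitor, a lower number a stronger inhibitor. Compound 1 (`CC(C)CN(Cc1ccc(C(=O)NO)cc1)S(=O)(=O)c1cc(F)c(F)c(F)c1F`) gives 520 nM, and compound 2 (`CC(C)N(Cc1ccc(C(=O)NO)cn1)S(=O)(=O)c1cc(F)c(F)c(F)c1F`) gives 1000 nM. For the measured compounds named here, these two values lie within the scatter of each other, so compound 1 cannot be ranked against the only other measured compound.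

The next compound to be read is compound 3 (`CC(C)N(Cc1ccc(C(=O)NO)cc1)S(=O)(=O)c1cc(F)c(F)c(F)c1F`), which carries isopropyl in place of isobutyl on a sulfonamide nitrogen. Going by the values given here, no measured pair shows a single change of any kind, so the data offer no direct precedent for the size of this step. The change is confined to one chain, and with compound 1 at 520 nM as the starting point, no step beyond the scatter is expected in this assay, in either direction. The estimated step is a 1.2-fold higher number from compound 1 to compound 3 (0.06 log units; within the scatter). Compound 3 is expected at 600 nM, with an estimated range of 220 nM to 1500 nM.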

Compound 3, half-maximal inhibitory concentration: 1190 nM
Compound 3: middle estimate off by 2.0-fold (0.30 log units), on the low side; the range from low to high includes it.
By their numbers in this assay, from the lowest: compounds 1, 2 and 3 (each within the scatter of the next, the first and the last beyond it).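

In this assay, the sulfonamide nitrogen now has its first pair that differs in this one place: a 2.3-fold higher number from compound 1 to compound 3 (0.36 log units; beyond the scatter), a modest step, but one that lies beyond the scatter. The number therefore responds to the chain on this nitrogen, even when the change is only from isobutyl, with 4 heavy atoms, to isopropyl, with 3, and neither chain has a ring, a hydrogen-bond donor or a hydrogen-bond acceptor. Of these two chains, isobutyl gives the stronger inhibitor, but no measurement at hand explains the difference.

A single step does not show whether the trend continues beyond isobutyl, so a longer chain such as n-pentyl, a cyclopropylmethyl group or a chain ending in an amine on the same nitrogen remains an open comparison. Among the compounds shown here, it also remains open whether isobutyl in place of isopropyl would give a step of similar size on the core of compound 2, where the present data offer no matched pair.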